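A few compounds are considered here, and "the series" means these few. Any claim that something is new, unique, unknown or untested is made for them only; others in the source may bear on it.

In a functional assay on MCF7 cells (Homo sapiens) for inhibition, read by fluorescence, with a stated time of 72 h (a lower number here means a stronger inhibitor, a higher number a weaker inhibitor), compound 1 (`CC(C)n1cnc2c(NC(=N)N)nc(NCCCO)nc21`) gives 8800 nM, compound 2 (`CC(C)n1cnc2c(NC(=N)N)nc(NCCCCCCO)nc21`) gives 5200 nM and compound 3 (`CC[C@H](CO)Nc1nc(NC(=N)N)c2ncn(C(C)C)c2n1`) gives 4500 nM. Compound 3 thus stands within the scatter of both other compounds. Compound 4 (`CC(C)[C@H](CO)Nc1nc(NC(=N)N)c2ncn(C(C)C)c2n1`) differs from compound 3 by one change: methyl in place of hydrogen on a saturated chain carbon bound to two saturated chain carbons. The same difference reads 1-(hydroxymethyl)propyl to 1-(hydroxymethyl)-2-methylpropyl. The nearest evidence comes from side-chain swaps, not from this exact change: a 2.0-fold lower number from compound 1 to compound 3 (0.29 log units; within the scatter), a 1.2-fold lower number from compound 2 to compound 3 (0.06 log units; within the scatter) and a 1.7-fold lower number from compound 1 to compound 2 (0.23 log units; within the scatter). With all three steps inside the scatter, no step beyond the scatter is expected in this assay. The expected step is a 1.1-fold lower number from compound 3 to compound 4 (0.05 log units; within the scatter). The estimate for compound 4 is 4000 nM, with an expected range of 1800 nM to 9000 nM.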

Compound 4, half-maximal inhibitory concentration: 10500 nM
Beside the measured number, compound 4's estimate is 2.6-fold (0.42 log units) below it; the whole stated range lies below it.
By their numbers in this assay, from the lowest: compounds 3, 2, 1 and 4 (each within the scatter of the next, the first and the last beyond it).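

In this assay, within the data shown here, methyl in place of hydrogen on a saturated chain carbon bound to two saturated chain carbons gives the first step beyond the scatter (a 2.3-fold higher number from compound 3 to compound 4 (0.37 log units; beyond the scatter)). The 1-(hydroxymethyl)-2-methylpropyl side chain also separates from 6-hydroxyhexyl (a 2.0-fold higher number from compound 2 to compound 4 (0.31 log units; beyond the scatter)), but not from 3-hydroxypropyl (a 1.2-fold higher number from compound 1 to compound 4 (0.08 log units; within the scatter)). Nothing shown accounts for the shift from ethyl to isopropyl at this carbon.

As far as these compounds go, whether phenyl, tert-butyl or an amine-bearing chain at this carbon would carry the number further remains open.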